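Lengthening the Alkenyl Chain of the Amide in Compound 4

The compounds below may be only part of what the source reports. "The series", "measured", "known", "first", "only" and "open" are said of these compounds alone.

Compound 1, `C=C(F)C(=O)Nc1cc(Nc2nccc(-c3cn(C)c4ccccc34)n2)c(OC)cc1N(C)CCN(C)C`: 3790 nM
Compound 2, `COc1cc(N(C)CCN(C)C)c(NC(=O)C(Cl)=C(Cl)Cl)cc1Nc1nccc(-c2cn(C)c3ccccc23)n1`: a limit, > 50000 nM
Compound 3, `COc1cc(N(C)CCN(C)C)c(NC(=O)C=C(C)C)cc1Nc1nccc(-c2cn(C)c3ccccc23)n1`: 5660 nM

All three compounds share one core and differ only in the group on the carbonyl carbon of the amide. In a functional assay on HepG2 cells (Homo sapiens) for antiproliferative activity, read by MTT assay, with a stated time of 72 h (on this read-out higher numbers stand for weaker inhibition and lower numbers for stronger inhibition), compound 3 gives the highest of the two numbers that were obtained. Compound 1 lies close to it, with a 1.5-fold higher number from compound 1 to compound 3 (0.17 log units; within the scatter). For compound 2 the result is only (the limit of > 50000 nM in this assay, at which 1 of the 3 values shown sits), so no number is known for it. The two steps that reach compound 2 are large: an at least 13-fold higher number from compound 1 to compound 2 (1.12 log units; beyond the scatter) and an at least 8.8-fold lower number from compound 2 to compound 3 (0.94 log units; beyond the scatter).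

Compound 4, `COc1cc(N(C)CCN(C)C)c(NC(=O)/C=C\C(C)C)cc1Nc1nccc(-c2cn(C)c3ccccc23)n1`, differs from compound 3 by 3-methylbut-1-en-1-yl in place of 2-methylprop-1-en-1-yl on a carbonyl carbon. The step from compound 1 to compound 3 is the one that bears on this change, since it also exchanges one hydrocarbon alkenyl group for another, and it stayed within the scatter with a 1.5-fold higher number from compound 1 to compound 3 (0.17 log units; within the scatter). The large steps all involve the trichloroethenyl group of compound 2, which is absent here. For compound 4 the expected step is therefore a 1.1-fold higher number from compound 3 to compound 4 (0.03 log units; within the scatter), no change beyond the scatter. Compound 4 is estimated at 6000 nM, expected to fall between 2500 nM and 15000 nM.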

Compound 4, half-maximal inhibitory concentration: 4390 nM
Beside the measured number, compound 4's estimate is 1.4-fold (0.14 log units) above it; measured number inside the range.
By their numbers in this assay, from the lowest: compounds 1, 4 and 3 (each within the scatter of the next). At a limit, above all of these: compound 2.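

Lengthening the group on the carbonyl carbon from 2-methylprop-1-en-1-yl to 3-methylbut-1-en-1-yl, which goes from 4 carbon atoms to 5, makes no difference beyond the scatter in this assay, with a 1.3-fold lower number from compound 3 to compound 4 (0.11 log units; within the scatter). The comparison with the 1-fluoroethenyl group reads the same, with a 1.2-fold higher number from compound 1 to compound 4 (0.06 log units; within the scatter), so compounds 1, 3 and 4 all sit within the scatter of one another, and at this position a longer branched alkenyl chain is tolerated as well as the two earlier groups; compound 2 is the one that goes against this picture. The new step to the trichloroethenyl compound is large, with an at least 11-fold lower number from compound 2 to compound 4 (1.05 log units; beyond the scatter), but it gives only a minimum size, since compound 2 has no exact number and is held by a limit: the limit of > 50000 nM in this assay, at which 1 of the 4 values shown sits.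

Every group shown here is an alkenyl group, so it remains open how a saturated chain such as propyl, or an alkenyl chain ending in a dimethylamino group, would behave at this position. Compound 4 is also shown with only one geometry at its double bond, which leaves the other geometric isomer open.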